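This account rests on a few compounds, and the source may have more. Where it says the series, first, only, none or still open, it means among the compounds named here.

The study centres on compound 1 `CC1(C)N=C(N)N=C(N)N1c1cccc(F)c1` and its partner compound 2 `CCCCCCCCCCCCOc1cccc(N2C(N)=NC(N)=NC2(C)C)c1`. In a functional assay on L5178Y cells (Mus musculus) for inhibition (on this read-out lower numbers stand for lower potency and higher numbers for higher potency (the scale is a negative logarithm)), compound 1 gives 7.94, the higher of the two numbers recorded so far. Compound 2, carrying the long dodecyloxy chain, gives 6.41 in this assay, a gap beyond the usual scatter, so compound 1 stands clearly ahead of compound 2 on this read-out.

The next compound, compound 3 `CC(=O)c1cccc(N2C(N)=NC(N)=NC2(C)C)c1`, has not yet been measured. Relative to compound 1 the change is acetyl in place of fluoro on an aromatic carbon. Among the compounds with values here, no step between two measured compounds reports what such a swap does, so the expectation rests on compound 1 alone. Within the data shown here, a moderate fall in this assay is expected, because compound 1 with its fluoro reaches 7.94 while the larger acetyl has no precedent here; the step expected is a number 0.64 log units lower from compound 1 to compound 3 (beyond the scatter). Compound 3 is therefore estimated at 7.3, within the range 6.5 to 8.1.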

Compound 3, logarithm of the reciprocal of the active concentration, log(1/C): 6.96
Estimate against measurement, compound 3: 0.34 log units above; measured number inside the range.
By their numbers in this assay, from the lowest: compound 2; then compound 3; then compound 1.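

Within the data shown here, replacing fluoro with acetyl on this aromatic carbon gives a number 0.98 log units lower from compound 1 to compound 3 (beyond the scatter), the first step that isolates a single change at this place. It shows that in this assay the group held here, meta to a large group, affects the read-out, yet compound 3 with its acetyl still gives 6.96. No measurement at hand explains this step, so what drives it remains unknown.

The compounds shown cannot separate the contribution of the carbonyl from that of the larger group as a whole, since only this one swap has been isolated. Going by these compounds, it also remains open how an amine, a carboxylic acid or a chloro group at the same aromatic carbon would compare with fluoro and acetyl.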